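A few compounds are considered here, and "the series" means these few. Any claim that something is new, unique, unknown or untested is made for them only; others in the source may bear on it.

The measured compounds are:
compound 1 `C=CC(=O)N1C(=O)CC(c2cccc(Cl)c2)Sc2ccccc21`, which in a functional assay on HL-60 cells (Homo sapiens) for cytotoxicity, read by CCK-8 assay, with a stated time of 24 h (on this read-out higher numbers stand for weaker inhibition and lower numbers for stronger inhibition), gives 93100 nM;
compound 2 `C=CC(=O)N1C(=O)CC(c2ccc(C(F)(F)F)cc2)Sc2ccccc21`, which in this assay gives 106000 nM.

Both compounds share one core and carry a single substituent on the aryl ring attached to it. The two numbers lie within the scatter of each other, so compound 2 does not stand apart from compound 1; both show only weak inhibition in this assay, and neither can be called the stronger or weaker of the pair.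

The next compound is compound 3 `C=CC(=O)N1C(=O)CC(c2ccc(Br)cc2)Sc2ccccc21`. Relative to compound 2 the change is bromo in place of trifluoromethyl on an aromatic carbon. Within the data shown here, no measured pair in this set shows what such an exchange does, so the expectation rests only on the two values at hand, which sit close together despite differing in the same position. Compound 3 is therefore expected to give a number near that of compound 2, with a step of a 1.1-fold lower number from compound 2 to compound 3 (0.05 log units; within the scatter) that is not expected to exceed the scatter in either direction. For compound 3 the estimate in this assay is 95000 nM, within a range from 40000 nM to 250000 nM.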

Compound 3, half-maximal inhibitory concentration: 126000 nM
Compound 3: the middle estimate sits 1.3-fold (0.12 log units) below what was measured, and the stated range covers the measured number.
By their numbers in this assay, from the lowest: compounds 1, 2 and 3 (each within the scatter of the next).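

In this assay the first exchange seen at this position, bromo in place of trifluoromethyl on an aromatic carbon para to a large group, gives a 1.2-fold higher number from compound 2 to compound 3 (0.08 log units; within the scatter) and so does not separate the two compounds, even though a group of four heavy atoms gives way to a single atom. The exchange of 3-chlorophenyl for 4-bromophenyl on a saturated ring carbon gives a 1.4-fold higher number from compound 1 to compound 3 (0.13 log units; within the scatter) and likewise leaves the two compounds unresolved, so all three aryl groups shown fall within the scatter and remain weak on this read-out. No available evidence bears on this result.

What the compounds shown leave open is whether any group on this aryl ring can move the number beyond the scatter, for instance an amine, a carboxylic acid or a hydroxyl group, or simply an unsubstituted phenyl ring. They also leave open what would happen if the acryloyl group on the shared core gave way to a saturated propanoyl group.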